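Alkyne pyridine amides: from piperidine to piperazine

The compounds below may be only part of what the source reports. "The series", "measured", "known", "first", "only" and "open" are said of these compounds alone.

Compounds measured so far:
compound 1, `NC(=O)c1ccc(C#Cc2ccccc2)nc1`, 6600 nM
compound 2, `CC1CCN(C(=O)c2ccc(C#Cc3ccccc3)nc2)CC1`, 130 nM

The two measured compounds share a core and differ only at the carbonyl carbon. In a functional assay on BHK cells for positive allosteric modulation of metabotropic glutamate receptor 5 (Homo sapiens), read by FLIPR and calcium flux (on this read-out lower numbers stand for an effect already at smaller amounts and higher numbers for an effect only at larger amounts of compound), compound 1 gives 6600 nM, and compound 2 gives 130 nM. Going by the values given here, the single measured step, a 51-fold lower number from compound 1 to compound 2 (1.71 log units; beyond the scatter), is large and goes well beyond the scatter. Among the compounds with values here, compound 2 therefore stands at the lowest number of the two, with compound 1 the only neighbour, at a much higher number.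

Compound 3, `CN1CCN(C(=O)c2ccc(C#Cc3ccccc3)nc2)CC1`, has not been measured. Compared with compound 2 it carries 4-methylpiperazin-1-yl in place of 4-methylpiperidin-1-yl on a carbonyl carbon. Within the data shown here, no measured step bears directly on this exchange: the one step seen, a 51-fold lower number from compound 1 to compound 2 (1.71 log units; beyond the scatter), concerns the replacement of a small amino group by a full ring, not the swap of one ring atom for another within an otherwise similar ring. The expectation for compound 3 therefore rests mainly on compound 2 and is an estimate: a modest move toward higher numbers, a 3.1-fold higher number from compound 2 to compound 3 (0.49 log units; beyond the scatter), is expected, giving an estimated value of 400 nM with a range from 130 nM to 1300 nM.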

Compound 3, half-maximal effective concentration: 1600 nM
Beside the measured number, compound 3's estimate is 4.0-fold (0.60 log units) below it, outside the stated range (above it).
By their numbers in this assay, from the lowest: compound 2; then compound 3; then compound 1.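

In this assay the carbonyl carbon proves sensitive to a single ring atom: the six-membered ring and its heavy-atom count stay the same, yet 4-methylpiperazin-1-yl in place of 4-methylpiperidin-1-yl gives a 12-fold higher number from compound 2 to compound 3 (1.09 log units; beyond the scatter) and so gives back most of the gain that compound 2 had shown over compound 1. A full ring alone therefore does not account for that gain, since the exchange of the amino group for 4-methylpiperazin-1-yl yields only a 4.1-fold lower number from compound 1 to compound 3 (0.62 log units; beyond the scatter) where the exchange for 4-methylpiperidin-1-yl had given a large step. No measurement offered here accounts for the difference between these two rings.

The compounds shown leave open whether this loss follows the second ring nitrogen as such or depends on what that nitrogen carries. A morpholine amide, with an oxygen in that ring place, or a piperazine amide with an ethyl or longer chain, or an acetyl group, on that nitrogen would help to separate these readings.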